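Compound 4: a Second 4-Hydroxyphenyl Replaces 3-Hydroxyphenyl

A few compounds are considered here, and "the series" means these few. Any claim that something is new, unique, unknown or untested is made for them only; others in the source may bear on it.

Compound 1 `Oc1ccc(-c2cc(-c3ccccc3O)cc(-c3cccc(O)c3)n2)cc1` is examined in an ADME assay on HEK293 cells (Homo sapiens) for cytotoxicity, read by CCK-8 assay, with a stated time of 4 days (a lower number here means a stronger inhibitor, a higher number a weaker inhibitor), where compound 1 gives 5650 nM, the highest of the two numbers reported. Compound 3 `Oc1cccc(-c2cc(-c3ccccc3O)cc(-c3cccc(O)c3)n2)c1` gives 130 nM in this assay. Compound 2 `Oc1cccc(-c2cc(-c3cccc(O)c3)nc(-c3ccccc3O)c2)c1` reaches only the limit of > 50000 nM in this assay, and so supplies no number for comparison. Within the data shown here, the one measured step that bears on the change at hand is a 43-fold lower number from compound 1 to compound 3 (1.64 log units; beyond the scatter), and it runs in the opposite direction to what is now proposed.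

Compound 4 `Oc1ccc(-c2cc(-c3ccccc3O)cc(-c3ccc(O)cc3)n2)cc1` differs from compound 1 by 4-hydroxyphenyl in place of 3-hydroxyphenyl on an aromatic carbon. Since a 43-fold lower number from compound 1 to compound 3 (1.64 log units; beyond the scatter) was large, the reverse exchange in compound 4 is expected to push the number upward, toward weaker inhibition, and possibly beyond the range in which the assay reports a number at all. The limit of > 50000 nM in this assay, at which 1 of the 3 values shown sits, marks where compound 2 sits. Compound 4 is therefore expected to give about 40000 nM in this assay, within a range from 8000 nM to 200000 nM. The expected step is a 7.1-fold higher number from compound 1 to compound 4 (0.85 log units; beyond the scatter), with a real chance that only a limit will be recorded for compound 4.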

Compound 4, half-maximal inhibitory concentration: 780 nM
The estimate for compound 4 lay 51-fold (1.71 log units) above the measured number; measured number below the stated range.
By their numbers in this assay, from the lowest: compound 3; then compound 4; then compound 1. At a limit, above all of these: compound 2.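

In this assay, the exchange on an aromatic carbon next to the ring nitrogen gives a 7.2-fold lower number from compound 1 to compound 4 (0.86 log units; beyond the scatter) and so shows that 4-hydroxyphenyl in place of 3-hydroxyphenyl can lower the number at this place. The earlier step, a 43-fold lower number from compound 1 to compound 3 (1.64 log units; beyond the scatter) with 3-hydroxyphenyl in place of 4-hydroxyphenyl at the other place, also ran downward, so the two exchanges go in opposite senses and yet both lower the number. Among these three compounds, then, the hydroxyl position on one ring does not set the direction by itself: compound 1 carries one group of each kind, while compound 3 and compound 4 each carry two alike, a reading that holds for these three compounds only.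

On these data alone, whether the same downward step would hold with a 4-aminophenyl group or a 4-carboxyphenyl group at this place, or whether it needs the hydroxyl at all, stays open. No measurement among the compounds shown gives a reason for either step.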